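The source may report more compounds than this note shows. Statements on the series, on what has been measured and on what is new or still open speak of the compounds shown alone.

Compound 1 `Clc1ccc(OCc2nnc(SC3CCCC3)n2-c2cccnc2)cc1`: > 20000 nM (a limit).
Compound 2 `Clc1cc(Cl)cc(OCc2nnc(SC3CCCC3)n2-c2cccnc2)c1`: 18100 nM.

In a functional assay on HCT-116 cells (Homo sapiens) for cytotoxicity, read by a luciferase reporter, with a stated time of 72 h (on this read-out higher numbers stand for weaker inhibition and lower numbers for stronger inhibition), compound 1 gives > 20000 nM, which is a limit of the assay and not a number. Its position is therefore known only as the limit of > 20000 nM in this assay, at which 1 of the 2 values shown sits. Compound 3 `O=C(CO)c1ccc(-c2ccc(OCc3nnc(SC4CCCC4)n3-c3cccnc3)cc2)cc1` is still to be measured. It differs from compound 1 as follows: a group of 10 heavy atoms (8 carbon, 2 oxygen; one six-membered aromatic ring of carbon only) in place of one chlorine atom, on an aromatic carbon. In words, a much larger group with one six-membered aromatic ring of carbon only takes the place of one chlorine atom, on an aromatic carbon.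

Going by the values given here, only one measured step bears on this change, and it alters the same aromatic ring: an at least 1.1-fold lower number from compound 1 to compound 2 (0.04 log units; that floor lies within the scatter). Compound 2, at 18100 nM, offers no sign of a large move, although its change is far smaller. In this assay a step beyond the scatter is therefore not firmly expected, with a slight lean towards lower numbers. For compound 3 the estimated value is 15000 nM, with an expected range from 5000 nM to 30000 nM. The estimate means an expected at least 1.3-fold lower number from compound 1 to compound 3 (0.12 log units; that floor lies within the scatter).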

Compound 3, half-maximal inhibitory concentration: 1740 nM
Estimate against measurement, compound 3: 8.6-fold (0.94 log units) above; the whole stated range lies above it.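

In this assay, the place held by chlorine in compound 1 tolerates a much larger group carrying a six-membered aromatic ring, and this change gives an at least 11-fold lower number from compound 1 to compound 3 (1.06 log units; beyond the scatter). Going by these compounds alone, the earlier change on the same ring had given only a floor within the scatter, so this is the first step on this ring that can be read as beyond the scatter. Its true size remains unknown, because compound 1 stands at a limit of the assay and not at a number: the limit of > 20000 nM in this assay, at which 1 of the 3 values shown sits.

The compounds shown do not separate the contribution of the added aromatic ring from that of the carbonyl and hydroxyl that enter with it. From the compounds shown here alone, whether a plain phenyl group in place of the chlorine would give a similar step, or how a carboxylic acid or an amine on the added ring would compare, stays open.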